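The source may hold more compounds than are shown below. What is called first, only, known or untested is meant among the compounds shown, and "the series" means these compounds.

Measured so far in an assay on isolated protein for inhibition of serine/threonine-protein kinase 10 (Homo sapiens), read by thermal shift assay, tested at 10 uM; on this read-out lower numbers stand for weaker stabilisation of the target and higher numbers for stronger stabilisation of the target against heat:
compound 1 `CC(C)(C)c1cc(NC(=O)Nc2ccc(F)cc2)n(-c2ccccc2)n1`: 6.5 degrees C
compound 2 `CC(C)(C)c1cc(NC(=O)Nc2cc(C(F)(F)F)cc(C(F)(F)F)c2)n(-c2ccccc2)n1`: -0.5 degrees C
compound 3 `Cc1cc(C)cc(NC(=O)Nc2cc(C(C)(C)C)nn2-c2ccccc2)c1`: -0.3 degrees C

Compound 3 holds the second highest of the three numbers; its nearest neighbour is compound 2, lower by a difference within the scatter, and compound 1 stands well above it beyond the scatter. For the measured compounds named here, the one measured step at this position is a number 6.8 degrees C lower from compound 1 to compound 3 (beyond the scatter), a large loss on exchanging one aryl group on the amide-type nitrogen for another. Compound 4 `CC(C)(C)c1cc(NC(=O)Nc2ccccc2)n(-c2ccccc2)n1` is not yet measured; it differs from compound 3 by phenyl in place of 3,5-dimethylphenyl on an amide-type nitrogen, so the two methyls leave and an unsubstituted phenyl remains. Going by the values given here, no measured pair shows directly what removing those methyls does. Among the compounds with values here, compounds 2 and 3, each carrying two groups on that ring, sit near zero, whereas compound 1, carrying a single fluorine there, is the only high value. Compound 4, carrying nothing on that ring, is expected to recover part of the loss seen from compound 1, with a step of a number 4.3 degrees C higher from compound 3 to compound 4 (beyond the scatter). Within the data shown here, compound 4 is therefore estimated at 4 degrees C, with a range from 0.5 degrees C to 7.5 degrees C; the uncertainty is wide since no measured compound carries a bare phenyl at this place.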

Compound 4, shift of the target's melting temperature: 7.2 degrees C
The estimate for compound 4 lay 3.2 degrees C below the measured number; measured number inside the range.
By their numbers in this assay, from the lowest: compounds 2 and 3 (each within the scatter of the next); then compounds 1 and 4 (each within the scatter of the next).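

In this assay, the aryl ring on the amide-type nitrogen is not itself the source of the loss, since replacing 3,5-dimethylphenyl with phenyl gives a number 7.5 degrees C higher from compound 3 to compound 4 (beyond the scatter). Hydrogen in place of fluoro on an aromatic carbon gives a number 0.70 degrees C higher from compound 1 to compound 4 (within the scatter), so the fluorine of compound 1 is not needed for the high number. No available evidence explains either step.

On these data alone, whether one methyl on this ring is enough to cause the loss, or both are needed, remains open, as does whether a single trifluoromethyl would behave like the pair carried by compound 2. Also open, as far as these compounds go, is how an amine, a methoxy group or a carboxylic acid on this ring would compare with the bare phenyl of compound 4.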